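A few compounds are considered here, and "the series" means these few. Any claim that something is new, unique, unknown or untested is made for them only; others in the source may bear on it.

Working notes on the series. Of the compounds shown here, two on the shared core have been measured in an ADME assay on microsomes from liver (Mus musculus) for metabolic stability, read by LC-MS, using NADPH, with stated times of 15 min and 60 min, tested at 4.6 uM; a lower number here means that the compound disappears faster, a higher number that the compound lasts longer. Compound 1 `CC(C)CNC(=O)n1c(=O)oc2ccc(C3CCN(C)CC3)cc21` gives a half-life of 0.667 h in this assay. Compound 2 `CN1CCC(c2ccc3c(c2)oc(=O)n3C(=O)NCCCCc2ccccc2)CC1=O` gives a half-life of 0.583 h in this assay. The two values sit within the scatter of each other, so no order between compound 1 and compound 2 can be read from these numbers; both point to rapid disappearance under the conditions used.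

The next compound, compound 3 `CCN1CCN(c2ccc3c(c2)oc(=O)n3C(=O)NCCCCc2ccccc2)CC1`, differs from compound 2 at one place: 4-ethylpiperazin-1-yl in place of 1-methyl-2-oxopiperidin-4-yl on an aromatic carbon. Among the compounds with values here, no measured pair in the set shares this change, so there is no step to lean on, and the expectation rests only on the two values at hand. With both measured half-lives lying close together, the change from compound 2 to compound 3 is expected to move this assay by no more than the scatter, in no preferred direction, so a 1.1-fold lower number from compound 2 to compound 3 (0.03 log units; within the scatter) is the step expected.

For compound 3 the half-life in this assay is estimated at 0.55 h, with a range from 0.25 h to 1.2 h.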

Compound 3, half-life: < 0.0834 h
Compound 3: only a limit was reported (the forecaster's own chance of this, stated with the estimate: 5%); middle value at least 6.5-fold (0.81 log units) from the limit.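

This aromatic carbon, meta to a fused ring and para to a fused ring, is not a neutral place in this assay: placing 4-ethylpiperazin-1-yl there in place of 1-methyl-2-oxopiperidin-4-yl gives an at least 6.9-fold lower number from compound 2 to compound 3 (0.84 log units; beyond the scatter), whereas the two earlier values, lying within the scatter of each other, gave no sign that a single change could move this read-out so far. In this assay compound 3 gives < 0.0834 h, which is a limit of the assay and not a number. The step therefore fixes a minimum size and no exact size: the limit of < 0.0834 h in this assay, at which 1 of the 3 values shown sits.

The compounds shown leave open how far compound 3 lies past its limit, and whether the step follows the piperazine ring, its ethyl group or the loss of the ring carbonyl. A morpholin-4-yl group or a 4-acetylpiperazin-1-yl group on the same aromatic carbon, with the rest of compound 2 unchanged, would help to separate these parts of the change.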